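The source may report more compounds than this note shows. Statements on the series, on what has been measured and on what is new or still open speak of the compounds shown alone.

Measured compounds:
compound 1 `COc1cc(CCc2ccc(F)cc2)cc(OC)c1O` — 5470 nM
compound 2 `COc1cc(CCc2cccc(F)c2)cc(OC)c1O` — 12400 nM
compound 3 `COc1cc(CCc2ccccc2Cl)cc(OC)c1O` — 2190 nM

Three analogues sharing one core have been measured in a functional assay on HepG2 cells (Homo sapiens) for antiproliferative activity, read by MTT assay, with a stated time of 72 h; on this read-out higher numbers stand for weaker inhibition and lower numbers for stronger inhibition. Compound 1 gives 5470 nM in this assay, compound 2 gives 12400 nM, and compound 3 gives 2190 nM. Compound 3 stands at the lowest number of the three; its nearest neighbour is compound 1, whose number is higher by a margin beyond the usual scatter, and the furthest is compound 2, higher still and also beyond the scatter. So far compound 3 is the most potent of the measured set.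

Compound 4 `COc1cc(CCc2ccccc2)cc(OC)c1O` has not yet been measured in this assay. It differs from compound 3 in one place: hydrogen in place of chloro on an aromatic carbon. Among the compounds with values here, since no step between measured compounds matches this change, the direction can only be guessed from the fact that compound 3 carries the lowest number. A loss of potency beyond the scatter is expected from compound 3 to compound 4, as a 2.7-fold higher number from compound 3 to compound 4 (0.44 log units; beyond the scatter). Compound 4 is therefore estimated to give 6000 nM in this assay, within a range from 2500 nM to 15000 nM.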

Compound 4, half-maximal inhibitory concentration: 7830 nM
The estimate for compound 4 lay 1.3-fold (0.12 log units) below the measured number; low and high end bracket the measured number.
By their numbers in this assay, from the lowest: compound 3; then compounds 1, 4 and 2 (each within the scatter of the next, the first and the last beyond it).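

Set against compound 4, which carries hydrogen where compound 3 carries chloro, the chloro group on this aromatic carbon ortho to a large group matters in this assay: the change gives a 3.6-fold higher number from compound 3 to compound 4 (0.55 log units; beyond the scatter) and is a modest step. The fluoro compounds behave differently, since a 1.4-fold higher number from compound 1 to compound 4 (0.16 log units; within the scatter) and a 1.6-fold lower number from compound 2 to compound 4 (0.20 log units; within the scatter) are steps that leave the number for hydrogen indistinguishable from the number for either fluoro compound. Of the three halogen-bearing compounds, only compound 3 therefore stands clear of compound 4, and that finding rests on a single chloro compound.

Whether fluoro, bromo, a methoxy group, an amine or a carboxylic acid at the place of the chloro group would keep this step remains open, and no measurement at hand accounts for why the chloro step stands out from the fluoro steps.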